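This account rests on a few compounds, and the source may have more. Where it says the series, first, only, none or still open, it means among the compounds named here.

Measured so far:
compound 1 `Cc1nnc(SCc2cc(=O)c3ccccc3o2)s1` — in a functional assay on HeLa cells (Homo sapiens) for cytotoxicity, read by MTT assay, with a stated time of 72 h (a lower number here means a stronger inhibitor, a higher number a weaker inhibitor), compound 1 gives > 25000 nM, a limit of the assay.
compound 2 `Cc1ccc2oc(CSc3nnc(C)s3)cc(=O)c2c1` — in this assay compound 2 gives > 25000 nM, likewise a limit of the assay.

The step that the two limits leave unreadable from compound 1 to compound 2 is therefore not readable. Compound 2 stands at the limit of > 25000 nM in this assay, at which 2 of the 2 values shown sit.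

Compound 3 `Cc1ccc2oc(CSc3nnc(C)o3)cc(=O)c2c1` differs from compound 2 by 5-methyl-1,3,4-oxadiazol-2-yl in place of 5-methyl-1,3,4-thiadiazol-2-yl on a sulfur. Going by the values given here, no measured step bears on this exchange, and the one recorded step gives no readable size. Compound 3 is therefore expected to remain at the limit. The step that the limit leaves unreadable from compound 2 to compound 3 that this estimate means is expected to lie within the scatter. For compound 3 the estimate is 40000 nM, with the range 12000 nM to 150000 nM.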

Compound 3, half-maximal inhibitory concentration: > 25000 nM
Compound 3: no number, only a limit; the forecaster's own chance of this, stated with the estimate: 85%; the middle value is on the limit's open side.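

Compound 2 and compound 3 both stand at a limit rather than a number, so no new step can be read between them: the limit of > 25000 nM in this assay, at which 3 of the 3 values shown sit.

The compounds shown leave open whether exchanging 5-methyl-1,3,4-thiadiazol-2-yl for 5-methyl-1,3,4-oxadiazol-2-yl changes cytotoxicity at all.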